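Swapping 4-methylpiperidin-1-yl for (2-hydroxyethyl)amino in compound 4

A few compounds are considered here, and "the series" means these few. Any claim that something is new, unique, unknown or untested is made for them only; others in the source may bear on it.

Measured in a functional assay on HepG2 cells (Homo sapiens) for cytotoxicity, read by MTT assay, with a stated time of 72 h; a lower number here means a stronger inhibitor, a higher number a weaker inhibitor:
compound 1 `CC(C)n1c(Nc2ccccc2)nc2cnc(Nc3ccc(N4CCN(C)CC4)cc3)nc21`: > 5000 nM
compound 2 `Cc1cc(C)cc(-n2c(Nc3ccccc3)nc3cnc(Nc4ccc(N5CCN(C)CC5)cc4)nc32)c1`: > 5000 nM
compound 3 `CC1CCN(c2ccc(Nc3ncc4nc(Nc5ccccc5)n(C5CCCC5)c4n3)cc2)CC1`: > 5000 nM

Compound 3 gives > 5000 nM in this assay, which is a limit and not a number. For the measured compounds named here, it has no exact position, and neither has any other compound measured so far: the whole picture is the limit of > 5000 nM in this assay, at which 3 of the 3 values shown sit.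

Compound 4 `OCCNc1ccc(Nc2ncc3nc(Nc4ccccc4)n(C4CCCC4)c3n2)cc1` keeps the shared core of compound 3 and changes one group. The difference is (2-hydroxyethyl)amino in place of 4-methylpiperidin-1-yl on an aromatic carbon, para to a large group.

Going by the values given here, no measured step makes this exchange. The only one, a step that the two limits leave unreadable from compound 1 to compound 2, puts 3,5-dimethylphenyl in place of isopropyl on an aromatic nitrogen, so it concerns another place and gives no size to carry over. With nothing better to go on, no step beyond the scatter is expected in this assay, and no direction can be given.

The expected step is a step that the limit leaves unreadable from compound 3 to compound 4. The estimate for compound 4 is 6000 nM, with an expected range of 2000 nM to 20000 nM.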

Compound 4, half-maximal inhibitory concentration: > 5000 nM
Compound 4 gave a limit, no number; the forecaster's own chance of this, stated with the estimate: 70%; the middle value is on the limit's open side.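

Compound 3 and compound 4 each give a limit and not a number in this assay, so no step between them can be read, and the wider picture offers no exact value either: the limit of > 5000 nM in this assay, at which 4 of the 4 values shown sit.

The compounds shown leave open how strong any of them is, and whether (2-hydroxyethyl)amino in place of 4-methylpiperidin-1-yl changes that strength at all.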